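Phenoxy change on the shared core: compound 1 to compound 4

The compounds below may be only part of what the source reports. "The series", "measured", "known", "first", "only" and "open" are said of these compounds alone.

Measured so far in a functional assay on SK-MEL-2 cells (Homo sapiens) for inhibition, read by sulforhodamine B assay, with a stated time of 48 h; a lower number here means that less compound is tolerated, a higher number that more compound is tolerated:
Compound 1 `Nc1cc(N)c2nc(-c3ccccc3)c(Oc3ccc(Cl)c(Cl)c3)nc2c1` gives 89100 nM.
Compound 2 `COc1ccc(CNc2nc3cc(N)cc(N)c3nc2-c2ccccc2)cc1OC` gives only a limit, < 100000 nM.
Compound 3 `CCOC(=O)[C@H](CCC(=O)O)NC(=O)c1ccc(Sc2nc3cc(N)cc(N)c3nc2-c2ccccc2)cc1` gives only a limit, < 100000 nM.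

Within the data shown here, compound 1 therefore stands as the only numerical value in this assay; the other two readings sit at the limit of < 100000 nM in this assay, at which 2 of the 3 values shown sit. Compound 4 `Nc1cc(N)c2nc(-c3ccccc3)c(Oc3ccc(F)cc3)nc2c1` differs from compound 1 in one place: 4-fluorophenyl in place of 3,4-dichlorophenyl on an oxygen on an aromatic ring. Among the measured compounds shown here, no step between two measured compounds is available, so nothing measured speaks for a move in either direction. The expected step for this assay is none beyond the usual scatter, a 1.0-fold lower number from compound 1 to compound 4 (0.02 log units; within the scatter). For compound 4 the estimated value is 85000 nM, expected to fall between 35000 nM and 160000 nM.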

Compound 4, concentration lethal to 50% of the cells: < 100000 nM
Compound 4 ended at the assay's limit; the forecaster's own chance of this, stated with the estimate: 40%; the middle value lies beyond the limit too.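

In this assay, among these compounds, compound 4 gives only a limit, < 100000 nM, so no step from compound 1 to compound 4 can be read. The compounds shown leave open whether 4-fluorophenyl in place of 3,4-dichlorophenyl shifts the reading at all, and most readings here are limits: the limit of < 100000 nM in this assay, at which 3 of the 4 values shown sit.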